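Guanidine to amine on a second trifluoromethylphenoxy core

The source may hold more compounds than are shown below. What is called first, only, known or untested is meant among the compounds shown, and "the series" means these compounds.

Measured compounds:
compound 1 `CN(Cc1ccc(OCCCNC(=N)N)cc1)c1nc2ccc(Oc3ccc(C(F)(F)F)cc3)cc2s1` gives 212000 nM
compound 2 `CN(Cc1ccc(OCCCN)cc1)c1nc2ccc(Oc3ccc(C(F)(F)F)cc3)cc2s1` gives 248000 nM
compound 3 `CN(Cc1ccc(OCCCNC(=N)N)cc1)c1nc2ccc(Oc3cccc(C(F)(F)F)c3)cc2s1` gives 771000 nM

All three were read in an assay on cells for inhibition of Voltage-dependent T-type calcium channel subunit alpha-1H (Homo sapiens), read by FLIPR and calcium flux, with stated times of 600 s and 300 s; a higher number here means a weaker inhibitor, a lower number a stronger inhibitor. Compound 4 `CN(Cc1ccc(OCCCN)cc1)c1nc2ccc(Oc3cccc(C(F)(F)F)c3)cc2s1` awaits measurement in this assay.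

Compound 4 is related to compound 3 by a hydrogen atom in place of a group of 3 heavy atoms (1 carbon, 2 nitrogen; no ring), on an amine nitrogen. The same change has been made once already, from compound 1 to compound 2: a hydrogen atom in place of a group of 3 heavy atoms (1 carbon, 2 nitrogen; no ring), on an amine nitrogen. There it moved the number only slightly, a 1.2-fold higher number from compound 1 to compound 2 (0.07 log units; within the scatter).

The two cores differ by 3-(trifluoromethyl)phenyl in place of 4-(trifluoromethyl)phenyl on an oxygen on an aromatic ring, which gave a 3.6-fold higher number from compound 1 to compound 3 (0.56 log units; beyond the scatter), a modest shift beyond the scatter. The place of the amine change is identical in its printed words for both pairs, so the change from compound 3 to compound 4 is the same kind of change on a core that differs only in the position of the trifluoromethyl group on the phenoxy ring.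

Expectation for compound 4 rests on compound 2, whose step a 1.2-fold higher number from compound 1 to compound 2 (0.07 log units; within the scatter) was within the scatter. The step from compound 3 to compound 4 is therefore expected to be a 1.2-fold higher number from compound 3 to compound 4 (0.07 log units; within the scatter). For compound 4 the estimate in this assay is 900000 nM, expected to lie between 400000 nM and 2000000 nM. Compound 3 already gives 771000 nM, the highest number among the three measured compounds, and compound 4 is expected to stand higher still.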

Compound 4, half-maximal inhibitory concentration: 239000 nM
The estimate for compound 4 lay 3.8-fold (0.58 log units) above the measured number, outside the stated range (below it).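

In this assay, the guanidine-to-amine change does not carry over from one core to the other at the same size, for on the second core it gives a 3.2-fold lower number from compound 3 to compound 4 (0.51 log units; beyond the scatter): the same change on two cores in this assay, a 1.2-fold higher number (0.07 log units; within the scatter) from compound 1 to compound 2 and a 3.2-fold lower number (0.51 log units; beyond the scatter) from compound 3 to compound 4, 3.8-fold (0.58 log units) apart, beyond the scatter of two such steps
Moving from 4-(trifluoromethyl)phenyl to 3-(trifluoromethyl)phenyl likewise depends on what else the compound carries, and with the amine it gives a 1.0-fold lower number from compound 2 to compound 4 (0.02 log units; within the scatter): the same change on two cores in this assay, a 3.6-fold higher number (0.56 log units; beyond the scatter) from compound 1 to compound 3 and a 1.0-fold lower number (0.02 log units; within the scatter) from compound 2 to compound 4, 3.8-fold (0.58 log units) apart, beyond the scatter of two such steps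
Both comparisons rest on the same set of four compounds, so they show one case in which the two changes do not add up, but they do not show a cause or how the changes would behave on any other core.

Going by these compounds, it remains open whether the same dependence would appear with a longer chain or with a carboxylic acid in place of the guanidine or amine. Also open, on these data alone, is how a nitrile or a chlorine in place of trifluoromethyl would behave with these two end groups.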